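A few compounds are considered here, and "the series" means these few. Any claim that something is new, unique, unknown or untested is made for them only; others in the source may bear on it.

In a functional assay on TK-10 cells (Homo sapiens) for inhibition, read by sulforhodamine B assay, with a stated time of 48 h (on this read-out lower numbers stand for stronger inhibition of growth and higher numbers for weaker inhibition of growth), compound 1 `COc1ccc(-c2cc(/C=C/C(=O)c3ccc(N)cc3)[nH]n2)cc1` gives 13000 nM, and compound 2 `COc1cc(-c2cc(/C=C/C(=O)c3ccc(N)cc3)[nH]n2)cc(OC)c1OC` gives 17500 nM; the two numbers sit within the usual scatter of each other, so compound 2 stands on the same footing as compound 1. Compound 3 `COc1ccc(-c2cc(/C=C/C(=O)c3ccc(N)cc3)[nH]n2)cc1OC` differs from compound 2 by one change: hydrogen in place of methoxy on an aromatic carbon. Among the compounds with values here, with no measured step of this kind to lean on, and compounds 1 and 2 so close, the step from compound 2 to compound 3 is expected to be a 1.3-fold lower number from compound 2 to compound 3 (0.10 log units; within the scatter), nothing beyond the scatter in either direction. Compound 3 is therefore estimated at 14000 nM in this assay, with a range from 7000 nM to 28000 nM.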

Compound 3, concentration for total growth inhibition: 23000 nM
For compound 3 the middle estimate is 1.6-fold (0.22 log units) below the measured one, and the stated range covers the measured number.
By their numbers in this assay, from the lowest: compounds 1, 2 and 3 (each within the scatter of the next).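

In this assay this place on the aromatic ring, ortho to a methoxy group and meta to a large group, can now be read from both sides: hydrogen in place of methoxy gives a 1.3-fold higher number from compound 2 to compound 3 (0.12 log units; within the scatter) and methoxy in place of hydrogen gives a 1.8-fold higher number from compound 1 to compound 3 (0.25 log units; within the scatter) so neither step leaves the scatter. No measurement here offers an explanation for these steps. The compounds shown leave open whether a hydroxyl group, a fluorine atom or an amine at this place would give a number beyond the scatter.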